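Notes on the step from compound 1 to compound 3

A few compounds are considered here, and "the series" means these few. Any claim that something is new, unique, unknown or untested is made for them only; others in the source may bear on it.

Measured so far in a physicochemical assay for solubility, measured as kinetic solubility, at pH 2; a lower number here means a less soluble compound, a higher number a more soluble compound:
- compound 1 `CC(C)C(/C=C1\NC(=O)NC1=O)c1ccc(-c2ccc3cccc(F)c3c2)[nH]c1=O` gives 7500 nM
- compound 2 `CCC(/C=C1\OC(=O)NC1=O)(CC)c1ccc(-c2ccc3cccc(F)c3c2)[nH]c1=O` gives 13500 nM

Among the compounds with values here, compound 1 (7500 nM) and compound 2 (13500 nM) lie within the usual scatter of each other, so compound 1 has no clear separation from the only other number. Within the data shown here, these two compounds also differ in more than one place, and no measured pair isolates a single change.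

Compound 3 `CC(C)C(c1ccc(-c2ccc3cccc(F)c3c2)[nH]c1=O)C1NC(=O)NC1=O` has not yet been measured. The change from compound 1 to compound 3 is a group of 7 heavy atoms (3 carbon, 2 nitrogen, 2 oxygen; one five-membered non-aromatic ring with 2 hetero atoms) in place of a group of 8 heavy atoms (4 carbon, 2 nitrogen, 2 oxygen; one five-membered non-aromatic ring with 2 hetero atoms), on a saturated chain carbon bound to an aromatic carbon and a saturated chain carbon and the rest of the structure is shared. The group that enters is 2,5-dioxoimidazolidin-4-yl, on a saturated chain carbon bound to an aromatic carbon and a saturated chain carbon.

Among the measured compounds shown here, with no measured step to carry over, the expectation in this assay is a small move towards a higher number, with none beyond the scatter as the likeliest outcome. The estimate starts from compound 1 (7500 nM) and stays wide. For the measured compounds named here, the expected step is a 1.6-fold higher number from compound 1 to compound 3 (0.20 log units; within the scatter) and has no precedent. For compound 3 the estimated value is 12000 nM within an expected range (4000 nM to 40000 nM).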

Compound 3, solubility: 5800 nM
The estimate for compound 3 lay 2.1-fold (0.32 log units) above the measured number; low and high end bracket the measured number.
By their numbers in this assay, from the lowest: compounds 3, 1 and 2 (each within the scatter of the next, the first and the last beyond it).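

Within the data shown here, this is the first pair that isolates a single change. On a saturated chain carbon bound to an aromatic carbon and a saturated chain carbon, 2,5-dioxoimidazolidin-4-yl replaces the group of 8 heavy atoms, and in this assay the result is a 1.3-fold lower number from compound 1 to compound 3 (0.11 log units; within the scatter). The entering group has one heavy atom and one double bond outside aromatic rings fewer than the leaving group, with the same counts of hydrogen-bond donors and acceptors, and at this position the change gives no separation from compound 1 that can be told from the scatter; no measurement available here bears on the origin of this result.

Compound 2 differs from both other compounds in more than one place, so what the ring oxygen and the diethyl-substituted carbon each contribute cannot be read from it. Also open, going by these compounds, is whether an amine or a carboxylic acid on the same saturated chain carbon, in place of 2,5-dioxoimidazolidin-4-yl, would give a step beyond the scatter in this assay.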